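Chain length between the two carbonyls and hydroxamate potency

The source may report more compounds than this note shows. Statements on the series, on what has been measured and on what is new or still open speak of the compounds shown alone.

Measured compounds:
compound 1, `O=C(CCCCCCC(=O)NCCNc1nonc1/C(=N/O)Nc1ccc(F)c(Br)c1)NO`, gives 140 nM
compound 2, `O=C(CCCCC(=O)NCCNc1nonc1/C(=N/O)Nc1ccc(F)c(Br)c1)NO`, gives 123 nM

In an assay on isolated protein for inhibition of Indoleamine 2,3-dioxygenase 1 (Homo sapiens) (a higher number here means a weaker inhibitor, a lower number a stronger inhibitor), compound 2 stands at the lower of the two numbers, but its neighbour compound 1 sits only a 1.1-fold lower number from compound 1 to compound 2 (0.06 log units; within the scatter) away, a gap within the scatter, so the two cannot be ranked. Compound 3, `O=C(CCCCCC(=O)NCCNc1nonc1/C(=N/O)Nc1ccc(F)c(Br)c1)NO`, has not been measured yet. It differs from compound 2 by (hydroxycarbamoyl)methyl in place of hydroxycarbamoyl on a saturated chain carbon, four bonds along the chain from a carbonyl carbon; the same difference, cut one bond further out, reads (hydroxycarbamoyl)methyl to 2-(hydroxycarbamoyl)ethyl. For the measured compounds named here, the only measured step that bears on this change is the one from compound 1 to compound 2, a 1.1-fold lower number from compound 1 to compound 2 (0.06 log units; within the scatter), which removed two chain carbons and left the number essentially unchanged. Compound 3 sits between the two measured chain lengths, so no step beyond the scatter is expected in either direction. For compound 3 the step from compound 2 is estimated at a 1.1-fold higher number from compound 2 to compound 3 (0.02 log units; within the scatter). The estimate for compound 3 in this assay is 130 nM, with a range from 65 nM to 260 nM.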

Compound 3, half-maximal inhibitory concentration: 113 nM
Beside the measured number, compound 3's estimate is 1.2-fold (0.06 log units) above it; the measured number falls inside the stated range.
By their numbers in this assay, from the lowest: compounds 3, 2 and 1 (each within the scatter of the next).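

Across this stretch of the chain, the change on the saturated chain carbon, four bonds along the chain from a carbonyl carbon, gives a 1.1-fold lower number from compound 2 to compound 3 (0.04 log units; within the scatter) in this assay and stays within the scatter. The wider comparison, at the place five bonds along the chain from a carbonyl carbon, gives a 1.2-fold lower number from compound 1 to compound 3 (0.09 log units; within the scatter) and also stays within the scatter. For the compounds shown here, compounds 1 and 2 alone showed only that the two outer lengths could not be ranked, whereas compound 3 now shows that the length lying inside that span does not stand apart from either of them, so all three hydroxamates can be treated as one group, with no preferred length among them in this assay.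

As far as these compounds go, what remains open is whether this tolerance extends to a longer chain such as a 5-(hydroxycarbamoyl)pentyl end, to a much shorter chain, or to a carboxylic acid or a primary amide in place of the hydroxycarbamoyl end. The compounds and values shown offer no independent evidence that would explain why the number holds steady over these three lengths.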